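This account rests on a few compounds, and the source may have more. Where it says the series, first, only, none or still open, it means among the compounds named here.

Compound 1 `CCN(CC)CC(=O)Nc1ccc(-c2nc3cc(C(F)(F)F)ccc3n2C)cc1`: 9000 nM
Compound 2 `Cn1c(-c2ccc(N)cc2)nc2cc(C(F)(F)F)ccc21`: 20000 nM
Compound 3 `CCC(=O)Nc1ccc(-c2nc3cc(C(F)(F)F)ccc3n2C)cc1`: 8000 nM

In an ADME assay on MT4 cells (Homo sapiens) for cytotoxicity, read by MTT assay, with a stated time of 96 h (on this read-out higher numbers stand for lower toxicity in this test and lower numbers for higher toxicity in this test), compound 1 stands second highest of these three numbers. Compound 3 lies within the scatter of it, while compound 2 sits further off, as a 2.2-fold higher number from compound 1 to compound 2 (0.35 log units; beyond the scatter) shows. Compound 4 `CCN(CC)CC(=O)Nc1ccc(-c2nc3cc(C(F)(F)F)ccc3[nH]2)cc1` differs from compound 1 in one place: hydrogen in place of methyl on an aromatic nitrogen. Among the measured compounds shown here, none of the measured steps touches this place. The three that exist, a 2.2-fold higher number from compound 1 to compound 2 (0.35 log units; beyond the scatter), a 2.5-fold lower number from compound 2 to compound 3 (0.40 log units; beyond the scatter) and a 1.1-fold lower number from compound 1 to compound 3 (0.05 log units; within the scatter), all change the group on a nitrogen elsewhere on the shared core, and they range from within the scatter to modest. For the measured compounds named here, with no step at the changed position to lean on, no shift beyond the scatter is expected in either direction. Compound 4 is therefore estimated at 9000 nM, with a range from 4000 nM to 20000 nM, which is expected to mean no change at the digits printed from compound 1 to compound 4 (within the scatter).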

Compound 4, half-maximal cytotoxic concentration: 8000 nM
The estimate for compound 4 lay 1.1-fold (0.05 log units) above the measured number; measured number inside the range.
By their numbers in this assay, from the lowest: compounds 3, 4 and 1 (each within the scatter of the next); then compound 2.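

The step at this position, a 1.1-fold lower number from compound 1 to compound 4 (0.05 log units; within the scatter), shows that in this assay hydrogen in place of methyl on the aromatic nitrogen leaves the number within the scatter. With the diethylamino side chain of compound 1 in place, this methyl therefore makes no measurable difference to the reading. Nothing measured here gives a reason for this result. Going by these compounds, whether a larger group on this nitrogen, such as ethyl or benzyl, would move the number stays open. Also open, on these data alone, is whether the same change would behave alike with the propanoyl group of compound 3 on the other nitrogen.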